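The source may hold more compounds than are shown below. What is called first, only, known or untested is meant among the compounds shown, and "the series" means these compounds.

Measured so far:
- compound 1, `O=C(Oc1cccc2cccnc12)c1cc2c(cc1Cl)SC(N(c1ccc(F)cc1)S(=O)(=O)c1ccc(Br)s1)=NS2(=O)=O`: 3400 nM
- compound 2, `Cc1cc2c(cc1Cl)SC(N(c1ccc(Cl)cc1)S(=O)(=O)c1ccccc1)=NS2(=O)=O`: 9200 nM

Both compounds were tested in a functional assay on A-427 cells (Homo sapiens) for cytotoxicity, with a stated time of 96 h; on this read-out lower numbers stand for stronger inhibition of growth and higher numbers for weaker inhibition of growth. Compound 1 gives 3400 nM, and compound 2 gives 9200 nM. Of these two numbers, compound 1 stands on the lower one, and the gap to compound 2 lies beyond the usual scatter of repeated measurements; the two compounds differ in several places at once, so the gap cannot be tied to any single change.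

Compound 3, `O=C(Oc1cccc2cccnc12)c1cc2c(cc1Cl)SC(N(c1ccc(F)cc1)S(=O)(=O)c1ccc(Cl)cc1)=NS2(=O)=O`, has not yet been measured in this assay. It differs from compound 1 in exactly one place: 4-chlorophenyl in place of 5-bromothiophen-2-yl on a sulfonyl sulfur. For the measured compounds named here, both groups are single aromatic rings attached to the same sulfonyl sulfur, and nothing among the measured compounds isolates the effect of such an exchange. Going by the values given here, with no comparable step available, the step from compound 1 to compound 3 is expected to be small, in no particular direction, and to stay within the scatter, as a 1.2-fold higher number from compound 1 to compound 3 (0.07 log units; within the scatter).

Compound 3 is therefore estimated to give about 4000 nM in this assay, with a likely range from 1500 nM to 11000 nM.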

Compound 3, concentration for 50% growth inhibition: 3100 nM
Compound 3: middle estimate off by 1.3-fold (0.11 log units), on the high side, within the range that was stated.
By their numbers in this assay, from the lowest: compounds 3 and 1 (each within the scatter of the next); then compound 2.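

For the compounds shown here, the exchange of 5-bromothiophen-2-yl for 4-chlorophenyl on the sulfonyl sulfur gives a 1.1-fold lower number from compound 1 to compound 3 (0.04 log units; within the scatter) in this assay, the first comparison here that changes only this one place. The result shows that the five-membered aromatic ring with its sulfur and bromine and the six-membered carbon ring with its chlorine cannot be told apart on this read-out, at least on the background of compound 1. Nothing available explains why the two groups read alike.

As far as these compounds go, both groups are single aromatic rings carrying a halogen, so it remains open whether the read-out would hold with a ring lacking the halogen, or with a carboxylic acid, an amine or a plain methyl group on the sulfonyl sulfur. From the compounds shown here alone, it also remains open whether this exchange would read the same way on the background of compound 2, which differs from compound 1 in several places at once.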